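The source may hold more compounds than are shown below. What is called first, only, known or untested is meant among the compounds shown, and "the series" means these compounds.

Measured compounds and their values in a functional assay on HCT-116 cells (Homo sapiens) for cytotoxicity, read by MTT assay, with a stated time of 48 h; a lower number here means a stronger inhibitor, a higher number a weaker inhibitor:
compound 1 `CNC(=O)c1cc(Oc2cccc(NC(=S)Nc3ccc(Cl)cc3Cl)c2)ccn1` gives 41200 nM;
compound 2 `O=C(NC1CCCCC1)c1cc(Oc2cccc(NC(=S)Nc3ccc(F)c(F)c3)c2)ccn1` gives 8900 nM;
compound 3 `CNC(=O)c1cc(Oc2cccc(NC(=S)Nc3cccc(C(F)(F)F)c3)c2)ccn1` gives 25300 nM.

Compound 3 stands second highest of the three numbers. Its nearest neighbour is compound 1, and that step, a 1.6-fold lower number from compound 1 to compound 3 (0.21 log units; within the scatter), changes 3-(trifluoromethyl)phenyl for 2,4-dichlorophenyl on an amide-type nitrogen; compound 2 sits further away with the lowest number, but it differs from compound 3 in two places, so its gap to compound 3 cannot be read as a single step.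

Compound 4 `O=C(c1cc(Oc2cccc(NC(=S)Nc3cccc(C(F)(F)F)c3)c2)ccn1)N1CCCC1` differs from compound 3 in one place: pyrrolidin-1-yl in place of methylamino on a carbonyl carbon. Among the measured compounds shown here, no measured step touches this carbonyl carbon; the only counted step, from compound 1 to compound 3, acts elsewhere and does not bear on it. Compound 2, which carries a larger group on its carbonyl carbon, shows a lower number than compound 3, but its second difference leaves that unassigned. A small step, expected as a 1.6-fold lower number from compound 3 to compound 4 (0.20 log units; within the scatter), is therefore the most that can be anticipated. Compound 4 is estimated at 16000 nM, expected between 5000 nM and 50000 nM.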

Compound 4, half-maximal inhibitory concentration: 19200 nM
The estimate for compound 4 lay 1.2-fold (0.08 log units) below the measured number; the range from low to high includes it.
By their numbers in this assay, from the lowest: compound 2; then compounds 4, 3 and 1 (each within the scatter of the next, the first and the last beyond it).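

In this assay, among the compounds shown here, the first measured change on this carbonyl carbon, a 1.3-fold lower number from compound 3 to compound 4 (0.12 log units; within the scatter), shows that this position tolerates the exchange of methylamino for pyrrolidin-1-yl without a change beyond the scatter. The exchange takes away the hydrogen-bond donor of the methylamino group and brings in a five-membered non-aromatic ring with more heavy atoms, yet compound 3 and compound 4 cannot be told apart in this cytotoxicity read-out. No supporting measurement bears on why this exchange leaves the number within the scatter.

The compounds shown leave open whether a morpholin-4-yl ring or a longer chain such as hexylamino on this carbonyl carbon would move the number beyond the scatter. They also leave open whether pyrrolidin-1-yl would behave the same with 2,4-dichlorophenyl on the amide-type nitrogen.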